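The compounds below may be only part of what the source reports. "The series", "measured", "known", "first", "only" and "open" are said of these compounds alone.

Two compounds of the series carry numbers in a functional assay on DU-145 cells (Homo sapiens) for cytotoxicity, read by MTT assay, with a stated time of 72 h (on this read-out lower numbers stand for stronger inhibition and higher numbers for weaker inhibition), so far. Compound 1 `COc1ccc(/C(=C\c2c[nH]c3ccc(OCc4ccccc4)cc23)C(=O)O)cc1` gives 38100 nM in this assay and stands as the higher of the two numbers. For the measured compounds named here, compound 2 `COc1ccc(/C(=C\c2cn(C(C)=O)c3ccc(OCc4ccccc4)cc23)C(=O)O)cc1` gives 910 nM in this assay, and the only single-point step known is a 42-fold lower number from compound 1 to compound 2 (1.62 log units; beyond the scatter), which concerns the aromatic nitrogen only.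

Compound 3 `O=C(O)/C(=C/c1c[nH]c2ccc(OCc3ccccc3)cc12)c1ccccc1` differs from compound 1 at a different site: hydrogen in place of methoxy on an aromatic carbon, the para position of the six-membered carbon ring relative to the large group. Going by the values given here, no measured step touches this ring or this methoxy group, so the step from compound 1 to compound 2 does not bear on the change to compound 3 and gives no guide to its direction. With nothing in the series to indicate movement, the expectation is a step of a 1.2-fold higher number from compound 1 to compound 3 (0.07 log units; within the scatter) in this assay, that is, none beyond the scatter, with a wide allowance for surprise in either direction. On that basis compound 3 is estimated at 45000 nM in this assay, within a range from 12000 nM to 160000 nM.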

Compound 3, half-maximal inhibitory concentration: 34700 nM
Beside the measured number, compound 3's estimate is 1.3-fold (0.11 log units) above it; low and high end bracket the measured number.
By their numbers in this assay, from the lowest: compound 2; then compounds 3 and 1 (each within the scatter of the next).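

In this assay the change of 4-methoxyphenyl to phenyl gives a 1.1-fold lower number from compound 1 to compound 3 (0.04 log units; within the scatter) and so stays within the scatter: with hydrogen on the aromatic nitrogen, the methoxy group on this ring can give way to hydrogen without a measurable shift in the number. For the compounds shown here, this is the first reading at this place, as the earlier step concerned the aromatic nitrogen only, and it shows that the two sites need not respond alike: the acetyl change moves the number far beyond the scatter, whereas this change does not. No measured evidence on the compounds speaks to why this substitution leaves the number in place.

The compounds shown leave open whether the same change holds when the aromatic nitrogen carries acetyl, since the methoxy group has been exchanged only in the compound with hydrogen on that nitrogen. They also leave open whether this place tolerates groups other than methoxy and hydrogen, such as a hydroxyl group, a fluorine atom, an amine or a longer ether chain, so the flat reading describes this one pair and no general rule for the ring.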